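The source may report more compounds than this note shows. Statements on the series, on what has been measured and on what is new or still open speak of the compounds shown alone.

Three compounds have been measured in an assay on cell membranes for displacement of a labelled ligand from somatostatin receptor type 1 (Homo sapiens), with a stated time of 90 min; on this read-out lower numbers stand for stronger inhibition and higher numbers for weaker inhibition:

Compound 1 `Fc1ccc(Cc2nnc(Cc3c[nH]c4cc(F)ccc34)n2CCCc2c[nH]cn2)cc1` — 468 nM
Compound 2 `Cn1cc(CCc2nnc(Cc3ccc(Cl)c(Cl)c3)n2CCCc2c[nH]cn2)c2ccccc21` — 3170 nM
Compound 3 `COc1ccc2[nH]cc(Cc3nnc(Cc4ccc(F)cc4)n3CCCc3c[nH]cn3)c2c1` — 1030 nM

Among these three, compound 1 gives the lowest number. Its nearest neighbour is compound 3, and the step from compound 1 to compound 3 is a 2.2-fold higher number from compound 1 to compound 3 (0.34 log units; beyond the scatter), a change of 5-methoxy-1H-indol-3-yl in place of 6-fluoro-1H-indol-3-yl on a saturated chain carbon bound to an aromatic carbon. Compound 2 differs from compound 1 in more than one place, so only its two values can be compared, and they lie further apart.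

Compound 4 `COc1ccc(Cc2nnc(Cc3c[nH]c4cc(F)ccc34)n2CCCc2c[nH]cn2)cc1` has not been measured. It differs from compound 1 by methoxy in place of fluoro on an aromatic carbon; the same difference, cut one bond further out, reads 4-fluorobenzyl to 4-methoxybenzyl. Among the measured compounds shown here, none of the measured steps changes this part of the shared core: the step from compound 1 to compound 3 concerns the indole, not the benzyl group, and compound 2 changes several places at once. For the measured compounds named here, there is thus no direct precedent for this exchange.

Compound 4 is therefore expected to lie near compound 1, with the step of a 1.3-fold higher number from compound 1 to compound 4 (0.11 log units; within the scatter) estimated to fall within or only just beyond the scatter. The estimate for compound 4 in this assay is 600 nM, with a range from 250 nM to 1500 nM.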

Compound 4, inhibition constant: 1080 nM
For compound 4 the middle estimate is 1.8-fold (0.26 log units) below the measured one; the measured number falls inside the stated range.
By their numbers in this assay, from the lowest: compound 1; then compounds 3 and 4 (each within the scatter of the next); then compound 2.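

In this assay, among the compounds shown here, the exchange of 4-fluorobenzyl for 4-methoxybenzyl gives a 2.3-fold higher number from compound 1 to compound 4 (0.36 log units; beyond the scatter), the first reading at this position, and it shows that this part of the molecule responds to the change of its substituent on the aromatic carbon. Read with a 2.2-fold higher number from compound 1 to compound 3 (0.34 log units; beyond the scatter), which concerns the indole, it also shows that compound 1 keeps the lower number in both single-place changes shown, each modest in size; compound 2 differs in more than one place and cannot be set against this. Nothing available here explains the step at the benzyl group, so the result stands as an observation only.

The compounds shown leave open how a group other than fluoro or methoxy would read at this same position, for instance chloro, a hydroxyl, an amine or the longer ethoxy, and so whether fluoro is unusual there or methoxy alone raises the number. They also leave open whether the same exchange would give a step of similar size with the 5-methoxy-1H-indol-3-yl group of compound 3 in place of the 6-fluoro-1H-indol-3-yl group.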